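Swapping a cyclopropyl for a methyl at an aryl ether

A few compounds are considered here, and "the series" means these few. Any claim that something is new, unique, unknown or untested is made for them only; others in the source may bear on it.

Measured so far:
- Compound 1, `CC(C)Oc1ccccc1OC(C)C1=NCCN1`: 1580 nM
- Compound 2, `CC(Oc1ccccc1OC1CC1)C1=NCCN1`: 1050 nM

Of the compounds shown here, two have been tested in an assay on CHO cells for displacement of a labelled ligand from Alpha-2B adrenergic receptor (Homo sapiens); a lower number here means a stronger inhibitor, a higher number a weaker inhibitor. Compound 1 gives 1580 nM, and compound 2 gives 1050 nM. Compound 2 thus has the lower of the two numbers, but the gap to compound 1, a 1.5-fold lower number from compound 1 to compound 2 (0.18 log units; within the scatter), is within the scatter, so the two cannot be told apart on these data.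

Compound 3, `COc1ccccc1OC(C)C1=NCCN1`, has not yet been measured. It differs from compound 2 in one place: methyl in place of cyclopropyl on an oxygen on an aromatic ring. Within the data shown here, the only step known so far, a 1.5-fold lower number from compound 1 to compound 2 (0.18 log units; within the scatter), also changed the group on that same oxygen, from isopropyl to cyclopropyl, and produced no change beyond the scatter. That step is the one that bears on the present change, yet it does not involve a methyl, so there is no direct guide to how a smaller group on this oxygen behaves.

With only a single, flat step to go on, compound 3 is expected to land close to compound 2 in this assay, with no step beyond the scatter, a 1.0-fold higher number from compound 2 to compound 3 (0.02 log units; within the scatter). The estimate for compound 3 is 1100 nM, within a range of 350 nM to 3500 nM.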

Compound 3, inhibition constant: 871 nM
Compound 3: middle estimate off by 1.3-fold (0.10 log units), on the high side; the range from low to high includes it.
By their numbers in this assay, from the lowest: compounds 3, 2 and 1 (each within the scatter of the next).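

The earlier pair compared only isopropyl and cyclopropyl, so compound 3 gives the first view of a single carbon on this oxygen, and in this assay that smaller group cannot be told apart from either of the other two: the swap from cyclopropyl to methyl gives a 1.2-fold lower number from compound 2 to compound 3 (0.08 log units; within the scatter) and the swap from isopropyl to methyl gives a 1.8-fold lower number from compound 1 to compound 3 (0.26 log units; within the scatter) and so neither step rises above the noise of the measurement. Removing the three-membered ring of cyclopropyl therefore leaves the number within the scatter, just as replacing isopropyl with that ring did, and these three compounds read alike whichever of the three groups sits on this oxygen. The data at hand offer no measurement that would explain this lack of change.

From the compounds shown here alone, what stays open is whether any group on this oxygen can move the number beyond the scatter, since all three tested are small and carry only carbon and hydrogen. A longer alkyl chain, an amine or a carboxylic acid attached here would test how far this flat picture extends.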